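A few compounds are considered here, and "the series" means these few. Any claim that something is new, unique, unknown or untested is made for them only; others in the source may bear on it.

Measured compounds:
Compound 1, `O=C(NCCCOc1ccc2nc(O)ccc2c1)N(C1CCCCC1)C1CC1`, gives 15% in a functional assay on the whole organism for inhibition, with Rattus norvegicus as the target, at a dose of 30 mg/kg by the oral route; a higher number here means more inhibition at the dose given (going by the name of the read-out), a lower number less inhibition.
Compound 2, `O=C(NCCCOc1ccc2nc(O)ccc2c1)N(C1CC1)[C@H]1CCCC[C@H]1O`, gives 19% in this assay.

Compound 2 stands level with compound 1, the step of a number 4 percentage points higher from compound 1 to compound 2 (within the scatter) being within the scatter. Compound 3, `O=C(NCCCOc1ccc2nc(O)ccc2c1)N(C1CC1)[C@H]1CCCC[C@@H]1O`, has not been measured. The change from compound 2 to compound 3 is the two compounds have the same atoms and bonds and differ only in configuration as drawn: 1 of 2 stereo elements differ; a stereocentre at a saturated ring carbon is drawn R in compound 2 and S in compound 3. Among the measured compounds shown here, no measured step turns a stereocentre at a saturated ring carbon from R to S; the only step at hand, a number 4 percentage points higher from compound 1 to compound 2 (within the scatter), brought in the hydroxy itself and stayed within the scatter. Accordingly no step beyond the scatter is expected in this assay, an estimated a number 2 percentage points lower from compound 2 to compound 3 (within the scatter). Compound 3 is expected to give 17%, between 5% and 30%.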

Compound 3, a percentage reported as inhibition, in the whole organism at one dose (the size of the read-out at that dose, not a potency): 13%
Compound 3: the middle estimate sits 4 percentage points above what was measured; low and high end bracket the measured number.
By their numbers in this assay, from the lowest: compounds 3, 1 and 2 (each within the scatter of the next).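

In this assay, turning a stereocentre at a saturated ring carbon from R to S gives a number 6 percentage points lower from compound 2 to compound 3 (within the scatter), so this change of configuration shows no effect beyond the scatter. The hydroxy in place of hydrogen on a saturated ring carbon, now seen in a second configuration, gives a number 2 percentage points lower from compound 1 to compound 3 (within the scatter), so neither drawn form stands apart from compound 1. The pair of compounds 2 and 3 tests configuration alone: the fact that compounds 2 and 3 differ only in the configuration as drawn.

On these data alone, whether an amine or a carboxylic acid in place of the hydroxy would give a step beyond the scatter stays open. The compounds shown also leave open what a longer chain on the shared core would do.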